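Moving a methyl group on a compound held at the limit

The source may hold more compounds than are shown below. What is called first, only, known or untested is meant among the compounds shown, and "the series" means these compounds.

In a functional assay on HEK293 cells (Homo sapiens) for cytotoxicity (a lower number here means that less compound is tolerated, a higher number that more compound is tolerated), compound 1 `COc1ccc([C@H]2CC(=O)N(c3cccc(O)c3)C2)cc1OC1CCCC1` gives > 10000 nM as a limit of the assay and not a number. Compound 2 `COc1ccc([C@H]2CC(=O)N(c3ccc(C)c(N)c3)C2)cc1OC1CCCC1` likewise gives > 10000 nM as a limit and not a number. The record so far is thus the limit of > 10000 nM in this assay, at which 2 of the 2 values shown sit, and compound 2 has no number of its own. Among the compounds with values here, the one measured step is a step that the two limits leave unreadable from compound 1 to compound 2 and it brought 3-amino-4-methylphenyl in place of 3-hydroxyphenyl on an amide-type nitrogen in a ring, so no size can be carried forward from it.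

Compound 3 `COc1ccc([C@H]2CC(=O)N(c3cccc(N)c3C)C2)cc1OC1CCCC1` shares the core of compound 2, and the change 3-amino-2-methylphenyl in place of 3-amino-4-methylphenyl on an amide-type nitrogen in a ring puts 3-amino-2-methylphenyl in place of 3-amino-4-methylphenyl on an amide-type nitrogen in a ring. The two have the same atoms, joined differently. Within the data shown here, the only anchor is compound 2 with its limit of > 10000 nM as the starting point for the expectation. In this assay the expected change is a step that the limit leaves unreadable from compound 2 to compound 3 and no shift beyond the scatter is foreseen, with no direction to be read from the data. For compound 3 the estimate is 20000 nM within an expected range of 10000 nM to 50000 nM and the assay will most likely report only a limit.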

Compound 3, half-maximal cytotoxic concentration: > 10000 nM
Compound 3 was reported as a limit; the forecaster's own chance of this, stated with the estimate: 90%; the middle value is on the limit's open side.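

In this assay, within the data shown here, compound 1, compound 2 and compound 3 all stand at a limit and not at a number, so no step among them can be read: the limit of > 10000 nM in this assay, at which 3 of the 3 values shown sit. The compounds shown leave open what cytotoxic concentration any of the three actually has and whether swapping the group on the amide-type nitrogen changes it at all.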